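The compounds below may be only part of what the source reports. "The series", "measured", "known", "first", "only" and "open" are said of these compounds alone.

Compound 1 `CC1=C(C(=O)Nc2ccc(F)c(Cl)c2)C(c2cccc(Oc3ccccc3)c2)NC(=S)N1` gives 12600 nM in a functional assay on CAKI-1 cells (Homo sapiens) for cytotoxicity, read by sulforhodamine B assay, with a stated time of 48 h; a higher number here means a weaker inhibitor of growth, a lower number a stronger inhibitor of growth. Compound 2 `CC1=C(C(=O)Nc2ccc(Cl)c(Cl)c2)C(c2cccc(Oc3ccccc3)c2)NC(=S)N1` gives 8510 nM. Compound 3 `COc1cccc(C2NC(=S)NC(C)=C2C(=O)Nc2ccc(Cl)c(Cl)c2)c1` gives 17800 nM.

Compounds 1 and 2 share the same core and differ in one place only: fluoro in place of chloro on an aromatic carbon. The step this makes is a 1.5-fold higher number from compound 2 to compound 1 (0.17 log units; within the scatter). Compounds 2 and 3 have different cores, and the difference is methyl in place of phenyl on an oxygen on an aromatic ring. The step that goes with it is a 2.1-fold higher number from compound 2 to compound 3 (0.32 log units; beyond the scatter), a modest shift toward weaker inhibition of growth, though it stays close to the edge of what repeated measurements usually show.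

Compound 4 `COc1cccc(C2NC(=S)NC(C)=C2C(=O)Nc2ccc(F)c(Cl)c2)c1` has not yet been measured. It stands to compound 3 as compound 1 stands to compound 2, the same change made on the other core: fluoro in place of chloro on an aromatic carbon. Because a 1.5-fold higher number from compound 2 to compound 1 (0.17 log units; within the scatter) lies within the scatter, a step of similar small size is expected from compound 3 to compound 4, namely a 1.2-fold higher number from compound 3 to compound 4 (0.09 log units; within the scatter). This expectation rests on that one measured pair alone. For compound 4 the expected value in this assay is 22000 nM, and the estimate is expected to fall between 11000 nM and 45000 nM.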

Compound 4, concentration for 50% growth inhibition: 49000 nM
Compound 4: the middle estimate sits 2.2-fold (0.35 log units) below what was measured; measured number above the stated range.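

Fluoro in place of chloro on the core of compound 3 gives a 2.8-fold higher number from compound 3 to compound 4 (0.44 log units; beyond the scatter) in this assay, and this step can't be told apart from the one measured on the other core: the same change on two cores in this assay, a 1.5-fold higher number (0.17 log units; within the scatter) from compound 2 to compound 1 and a 2.8-fold higher number (0.44 log units; beyond the scatter) from compound 3 to compound 4, 1.9-fold (0.27 log units) apart, within the scatter of two such steps. Methyl in place of phenyl on the oxygen gives a 3.9-fold higher number from compound 1 to compound 4 (0.59 log units; beyond the scatter), and this too matches its earlier counterpart within the scatter: the same change on two cores in this assay, a 2.1-fold higher number (0.32 log units; beyond the scatter) from compound 2 to compound 3 and a 3.9-fold higher number (0.59 log units; beyond the scatter) from compound 1 to compound 4, 1.9-fold (0.27 log units) apart, within the scatter of two such steps. Both changes therefore carry across these two cores without a detectable shift in size, but two pairs of steps do not make a general rule, and the fluoro step on the core of compound 2 is itself too small to show a real effect there.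

From the compounds shown here alone, it remains open whether a bromo group or a nitrile in place of the fluoro would fit the same picture. The same question stands for an ethyl group or a longer chain on the oxygen.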